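The source may hold more compounds than are shown below. What is called first, only, known or untested is meant among the compounds shown, and "the series" means these compounds.

Three compounds have been measured in a functional assay on C8166 cells (Homo sapiens) for cytotoxicity, read by MTT assay; on this read-out lower numbers stand for higher toxicity in this test and higher numbers for lower toxicity in this test:

- compound 1 `Cc1cc(S(N)(=O)=O)ccc1NC(=O)COc1ccc(Cl)cc1NC(=O)c1ccccc1`: 207000 nM
- compound 2 `Cc1ccc(C(=O)Nc2cc(Cl)ccc2OCC(=O)Nc2ccc(S(N)(=O)=O)cc2C)cc1`: 54200 nM
- compound 3 `Cc1cc(S(N)(=O)=O)ccc1NC(=O)COc1ccc(Cl)cc1NC(=O)c1ccccc1[N+](=O)[O-]`: 54800 nM

Compound 3 stands second highest of the three numbers; compound 2 sits right beside it, and only compound 1 is clearly apart, with a higher number. Compound 4 `Cc1cc(S(N)(=O)=O)ccc1NC(=O)COc1ccc(Cl)cc1NC(=O)c1cc(Cl)cc(Cl)c1` differs from compound 3 in one place: 3,5-dichlorophenyl in place of 2-nitrophenyl on a carbonyl carbon.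

Among the measured compounds shown here, two measured steps bear on this change, since both put a group onto the same ring on the carbonyl carbon that was bare in compound 1: a 3.8-fold lower number from compound 1 to compound 2 (0.58 log units; beyond the scatter) and a 3.8-fold lower number from compound 1 to compound 3 (0.58 log units; beyond the scatter). Swapping one such group for another gave a 1.0-fold higher number from compound 2 to compound 3 (0.00 log units; within the scatter), so the lowering seems tied to carrying a group there rather than to which group it is. Compound 4 carries two chlorines on that ring, so its number is expected near compound 2 and compound 3, with the step of a 1.4-fold lower number from compound 3 to compound 4 (0.14 log units; within the scatter) expected to stay within the scatter. Compound 4 is therefore estimated at 40000 nM, with a range from 15000 nM to 110000 nM.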

Compound 4, half-maximal cytotoxic concentration: 72400 nM
Compound 4: middle estimate off by 1.8-fold (0.26 log units), on the low side; measured number inside the range.
By their numbers in this assay, from the lowest: compounds 2, 3 and 4 (each within the scatter of the next); then compound 1.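

In this assay a third kind of substituted ring on the carbonyl carbon, 3,5-dichlorophenyl, joins the other two, with steps that stay within the scatter (a 1.3-fold higher number from compound 3 to compound 4 (0.12 log units; within the scatter)) and (a 1.3-fold higher number from compound 2 to compound 4 (0.13 log units; within the scatter)), while the step from the bare phenyl stays beyond it (a 2.9-fold lower number from compound 1 to compound 4 (0.46 log units; beyond the scatter)). All three substituted compounds therefore sit apart from compound 1, none goes against this, and the change holds even though 3,5-dichlorophenyl has no hydrogen-bond acceptors and 2-nitrophenyl has them. Nothing available explains why a substituted ring differs from bare phenyl.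

On these data alone, whether an amine or a carboxylic acid on this ring would fall in the same place remains open. So does the effect of a single chlorine, since the substituted rings shown differ in both their groups and where those groups sit.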